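This account rests on a few compounds, and the source may have more. Where it says the series, first, only, none or still open, it means among the compounds named here.

Working notes on the series. The shared core is seen in compound 1 `Nc1ccc(-c2nc3cc(Cl)c(Cl)cc3[nH]2)cc1`, which in an ADME assay on MDBK cells (Bos taurus) for cytotoxicity, read by MTT assay, with a stated time of 96 h (a lower number here means that less compound is tolerated, a higher number that more compound is tolerated), gives 7500 nM. Compound 2 `COc1ccc(-c2nc3cc(C(F)(F)F)ccc3[nH]2)c(OC)c1` returns only a limit of the assay, > 100000 nM. Compound 3 `COc1ccc(-c2nc3cc(C(F)(F)F)ccc3[nH]2)cc1` likewise returns only a limit, > 100000 nM. Within the data shown here, the single measured change between neighbours, a step that the two limits leave unreadable from compound 2 to compound 3, cannot be sized, as both ends rest on (the limit of > 100000 nM in this assay, at which 2 of the 3 values shown sit). Compound 3 thus stands at the top of what this assay reports, without a number of its own; of the three values shown, compound 1 alone carries a number.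

Compound 4 `O=C(CN1CCCC1)Nc1ccc(-c2nc3cc(C(F)(F)F)ccc3[nH]2)cc1` differs from compound 3 in one place: (((pyrrolidin-1-yl)methyl)carbonyl)amino in place of methoxy on an aromatic carbon. Among the measured compounds shown here, no measured step bears on this change; the one step available concerns a methoxy group and is unreadable in any case. For the measured compounds named here, the number recorded for compound 1 at 7500 nM shows that values within range are reached, but no step connects compound 1 to compound 3. The expectation for compound 4 is therefore a value that may fall within range of this assay, estimated at 60000 nM, between 15000 nM and 150000 nM. The expected step, an at least 1.6-fold lower number from compound 3 to compound 4 (0.22 log units; that floor lies within the scatter), is read from a limit end and is an estimate only.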

Compound 4, half-maximal cytotoxic concentration: 15000 nM
Compound 4: the middle estimate sits 4.0-fold (0.60 log units) above what was measured; the range from low to high includes it.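

In this assay, (((pyrrolidin-1-yl)methyl)carbonyl)amino in place of methoxy, on an aromatic carbon para to a large group, gives an at least 6.6-fold lower number from compound 3 to compound 4 (0.82 log units; beyond the scatter), the only readable step among those shown. This position therefore tolerates a change that registers in this read-out, and the change brings a compound with the trifluoromethyl substituent from the limit to a number. The size of the step stays open upward, because one of its ends rests on a limit: the limit of > 100000 nM in this assay, at which 2 of the 4 values shown sit.

The compounds shown leave open which part of the entering group goes with the step: an acetylamino group at this position would test the amide alone, while a piperidine or a dimethylamino group in place of the pyrrolidine would test the ring. Among these compounds, no step links compound 1, at 7500 nM, to the others, so a simple amino group on the trifluoromethyl-substituted core remains the missing neighbour that would connect the dichloro compound to this change.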